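The compounds below may be only part of what the source reports. "The series", "measured", "known", "first", "only" and "open" are said of these compounds alone.

Working notes on the series. In a functional assay on HL-60 cells (Homo sapiens) for inhibition, read by CCK-8 assay, with a stated time of 48 h, tested at 20 uM (on this read-out lower numbers stand for less inhibition of growth and higher numbers for more inhibition of growth at the one concentration tested), compound 1 (`Cc1ccc(S(=O)(=O)Oc2ccccc2/C=C(\C#N)C(=O)Nc2nnc(C)s2)cc1`) gives 78%. Compound 2 (`Cc1ccc(S(=O)(=O)Oc2ccccc2/C=C(\C#N)C(=O)Nc2nnc(Cc3ccc(F)cc3)s2)cc1`) has no single number: in this assay, compound 2 is reported only as "not active" (no number reported). Its standing is therefore known in words alone, and the gap to compound 1 cannot be sized. Compound 3 (`Cc1ccc(S(=O)(=O)Oc2ccccc2/C=C(\C#N)C(=O)Nc2nnc(Cc3cccc(F)c3)s2)cc1`) has not yet been measured. The structural change is 3-fluorophenyl in place of 4-fluorophenyl on a saturated chain carbon bound to an aromatic carbon: the same atoms joined differently, with 3-fluorophenyl in place of 4-fluorophenyl on a saturated chain carbon bound to an aromatic carbon. With compound 2 at "not active" (no number reported) as the closest reference, the step expected in this assay is small and not clearly beyond the scatter, and any movement would be towards more inhibition of growth. For compound 3 the estimated value is 15%, with an expected range from 0% to 40%.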

Compound 3, percent growth inhibition at one concentration: 11%
Compound 3: middle estimate off by 4 percentage points, on the high side; measured number inside the range.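

In this assay this position now has a first measured size: 3-fluorophenyl in place of hydrogen on a saturated chain carbon bound to an aromatic carbon gives a number 67 percentage points lower from compound 1 to compound 3 (beyond the scatter), so this place does not tolerate every change in this read-out. The step between compound 2 and compound 3 cannot be read, as compound 2 has only words, and the exchange of 4-fluorophenyl for 3-fluorophenyl therefore stays without a size. Nothing at hand bears on the reason for the large step.

Open, as far as these compounds go, is how much of the step belongs to the ring and how much to the fluorine, which a plain phenyl at the same place would address. Also open, from the compounds shown here alone, is whether a smaller group, such as a methyl, or an amine in place of the 3-fluorophenyl would keep the inhibition of compound 1.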